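Swapping the acyl group on a thiourea nitrogen

The source may hold more compounds than are shown below. What is called first, only, known or untested is meant among the compounds shown, and "the series" means these compounds.

Of the compounds shown here, three have been tested in an ADME assay on Huh-7 cells (Homo sapiens) for cytotoxicity; on this read-out lower numbers stand for higher toxicity in this test and higher numbers for lower toxicity in this test. Compound 1 `NC(=S)N1CCCc2c(OCCCCCOc3cccc4ccccc34)cccc21` reaches only a limit in this assay, > 50000 nM. Compound 2 `NC(=S)n1ccc2c(OCCCCCOc3ccc(Cl)cc3)cccc21` gives 24700 nM in this assay. Compound 3 `CN(C)c1ccc(C(=O)NC(=S)N2CCc3c(OCCCCCOc4ccc(Cl)cc4)cccc32)cc1` also reaches only a limit in this assay, > 50000 nM. Compound 3 therefore stands at the low-toxicity end of what has been measured, sharing (the limit of > 50000 nM in this assay, at which 2 of the 3 values shown sit). Among the compounds with values here, no step between two measured compounds is available for comparison.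

Compound 4 `S=C(NC(=S)N1CCc2c(OCCCCCOc3ccc(Cl)cc3)cccc21)Oc1ccccc1` differs from compound 3 by a group of 9 heavy atoms (7 carbon, 1 oxygen, 1 sulfur; one six-membered aromatic ring of carbon only) in place of a group of 11 heavy atoms (9 carbon, 1 nitrogen, 1 oxygen; one six-membered aromatic ring of carbon only), on an amide-type nitrogen, the change sitting on the amide-type nitrogen next to the thiocarbonyl carbon. The step of a number no higher from compound 3 to compound 4 (the limit leaves the size open) is expected to be none beyond the scatter. Compound 4 is expected to give 50000 nM, within 20000 nM to 120000 nM.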

Compound 4, half-maximal cytotoxic concentration: > 50000 nM
Compound 4: only a limit was reported (the forecaster's own chance of this, stated with the estimate: 60%); the middle value lies on the limit itself.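

Compound 3 and compound 4 both reach only a limit, so no step between them can be read: the limit of > 50000 nM in this assay, at which 3 of the 4 values shown sit.

The compounds shown leave open whether swapping the group on the amide-type nitrogen changes the read-out at all.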